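Triazine acrylamides on Ramos cells: removing the ring amino group

A few compounds are considered here, and "the series" means these few. Any claim that something is new, unique, unknown or untested is made for them only; others in the source may bear on it.

Measured so far in a functional assay on Ramos cells (Homo sapiens) for antiproliferative activity, read by CCK-8 assay, with a stated time of 24 h; on this read-out lower numbers stand for stronger inhibition and higher numbers for weaker inhibition:
compound 1 `C=CC(=O)Nc1cccc(Nc2ncnc(Nc3ccc(-c4ccc(F)nc4)cc3)n2)c1`: 59200 nM
compound 2 `C=CC(=O)Nc1cccc(Nc2ncnc(Nc3ccc(C(=O)Nc4ccc(C)cn4)cc3)n2)c1`: a limit only
compound 3 `C=CC(=O)Nc1cccc(Nc2nc(N)nc(Nc3ccc(OCCOC)cc3)n2)c1`: 18900 nM
compound 4 `C=CC(=O)Nc1cccc(Nc2ncnc(Nc3ccc(OCCOC)cc3)n2)c1`: not yet measured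

Compound 2 gives only a limit, > 100000 nM, in this assay. Compound 3 stands lowest of the two numbers, with compound 1 the nearer one, beyond the scatter. Going by the values given here, the single measured step, an at least 1.6-fold higher number from compound 1 to compound 2 (0.22 log units; that floor lies within the scatter), concerns the outer aryl substituent and, because one of its values sits at the limit (the limit of > 100000 nM in this assay, at which 1 of the 3 values shown sits), its size is not fully known.

Compound 4 differs from compound 3 only in hydrogen in place of amino on an aromatic carbon. Among the compounds with values here, no measured step touches this position on the shared core, so nothing indicates a direction for it. The change is small on an already weakly active compound, and the expectation is a step of a 1.6-fold higher number from compound 3 to compound 4 (0.20 log units; within the scatter), which is within the scatter. Compound 4 is therefore expected to give about 30000 nM in this assay, between 10000 nM and 90000 nM.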

Compound 4, half-maximal inhibitory concentration: 181000 nM
The estimate for compound 4 lay 6.0-fold (0.78 log units) below the measured number; the whole stated range lies below it.
By their numbers in this assay, from the lowest: compound 3; then compound 1; then compound 4.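

In this assay, the position between two ring nitrogen atoms now has its first measured step, and the change there is not neutral: hydrogen in place of amino gives a 9.6-fold higher number from compound 3 to compound 4 (0.98 log units; beyond the scatter). On the core without the amino group, 2-methoxyethoxy in place of 6-fluoropyridin-3-yl gives a 3.1-fold higher number from compound 1 to compound 4 (0.49 log units; beyond the scatter), so this outer group offers no gain over the fluoropyridine there. Compound 2 gives only a limit, and the step from it to compound 4 cannot be read: the limit of > 100000 nM in this assay, at which 1 of the 4 values shown sits.

From the compounds shown here alone, the amino step is known from one pair only, and its size with any other outer substituent remains open. Also open, going by these compounds, is whether a methylamino group, a hydroxyl group or a methyl group at this position would match amino or fall nearer to hydrogen.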